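Notes on three measured compounds and one untested analogue

The compounds below may be only part of what the source reports. "The series", "measured", "known", "first", "only" and "open" are said of these compounds alone.

Measured in a functional assay on PC-3 cells (Homo sapiens) for cytotoxicity, read by sulforhodamine B assay, with a stated time of 48 h; on this read-out lower numbers stand for stronger inhibition and higher numbers for weaker inhibition:
compound 1 `CC(=O)N1N=C(c2ccco2)CC1c1ccc([N+](=O)[O-])cc1`: 21300 nM
compound 2 `CC(=O)N1N=C(c2cccc3ccccc23)CC1/C=C/c1ccccc1`: 21100 nM
compound 3 `O=CCN1N=C(c2ccc3ccccc3c2)CC1c1cccc(Cl)c1Cl`: 17900 nM

All three numbers sit close together. Compound 3 is at the low end of the three, yet its gaps to compound 2 and to compound 1 both fall within the scatter, so no ranking among these three can be read from the data.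

Compound 4 `O=CCN1N=C(c2ccc3ccccc3c2)CC1/C=C/c1ccccc1` is not yet measured. Relative to compound 3 the change is 2-phenylethenyl in place of 2,3-dichlorophenyl on a saturated ring carbon; the rest of the molecule is unchanged. The same 2-phenylethenyl group is present in compound 2, which in this assay gives 21100 nM, a number close to that of compound 3. For the measured compounds named here, no measured pair isolates this single change, so the size of the step is open, but nothing among the three measured compounds points to a move beyond the scatter in either direction.

The number expected for compound 4 is 20000 nM, with a range from 8000 nM to 50000 nM. The estimated step from compound 3 to compound 4 is a 1.1-fold higher number from compound 3 to compound 4 (0.05 log units; within the scatter), in effect none beyond the scatter.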

Compound 4, half-maximal inhibitory concentration: 19100 nM
For compound 4 the middle estimate is 1.0-fold (0.02 log units) above the measured one; measured number inside the range.
By their numbers in this assay, from the lowest: compounds 3, 4, 2 and 1 (each within the scatter of the next).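

In this assay, for the compounds shown here, the step at the saturated ring carbon of the shared core is a 1.1-fold higher number from compound 3 to compound 4 (0.03 log units; within the scatter) and gives the first single-place comparison. At this position, the loss of both chlorine atoms and the entry of a double bond outside aromatic rings, with the heavy-atom count unchanged, leave the number within the scatter. Nothing available explains this outcome or bears on this step.

A saturated 2-phenylethyl chain, or a phenyl ring bearing an amine or a carboxylic acid, at this ring carbon remains an open test of whether any group here can move the number beyond the scatter. The compounds shown also include no pair that changes only the group on the ring nitrogen, so the contribution of formylmethyl against acetyl remains open.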